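The compounds below may be only part of what the source reports. "The series", "measured", "known", "first", "only" and "open" are said of these compounds alone.

Of the compounds shown here, two have been measured in a physicochemical assay for solubility, at pH 7.4; a lower number here means a less soluble compound, a higher number a more soluble compound. Compound 1 `Cc1cc(C)c(-c2cn(C)cn2)cc1NC(=O)c1ccc(OCc2ccccn2)cc1` gives 8000 nM, the higher of the two numbers. Compound 2 `Cc1cc(F)c(-c2ncc[nH]2)cc1NC(=O)c1ccc(OCc2ccccn2)cc1` gives 1000 nM, a gap beyond the usual scatter. Compound 3 `Cc1cc(C)c(-c2ccc(N)nn2)cc1NC(=O)c1ccc(OCc2ccccn2)cc1` has not yet been measured. It differs from compound 1 in one place: 6-aminopyridazin-3-yl in place of 1-methyl-1H-imidazol-4-yl on an aromatic carbon. Going by the values given here, no measured pair shows this change, so the direction of the step from compound 1 to compound 3 in this assay is open; the expected step is small, a 1.3-fold lower number from compound 1 to compound 3 (0.12 log units; within the scatter), not beyond the scatter. Compound 3 is therefore estimated at 6000 nM, within a range from 1500 nM to 25000 nM.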

Compound 3, solubility: 6000 nM
Compound 3: middle estimate and measured number agree at the digits printed; measured number inside the range.
By their numbers in this assay, from the lowest: compound 2; then compounds 3 and 1 (each within the scatter of the next).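

In this assay, putting 6-aminopyridazin-3-yl in place of 1-methyl-1H-imidazol-4-yl on this aromatic carbon gives a 1.3-fold lower number from compound 1 to compound 3 (0.12 log units; within the scatter). At this position, then, a six-membered aromatic ring can replace a five-membered one while the two numbers stay within the scatter of each other. Nothing available bears on this result.

On these data alone, whether a different group here could give a step beyond the scatter stays open. That holds for the same six-membered ring without its amine, and for a carboxylic acid in the amine's place.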